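The source may hold more compounds than are shown below. What is called first, only, known or untested is meant among the compounds shown, and "the series" means these compounds.

Working notes on the series.

Compound 1 `CC(=O)N1CCC(NS(=O)(=O)c2ccc(NC(=O)c3ccccc3C)c3ccccc23)CC1` carries an acetyl group on the piperidine nitrogen of the shared core, and in an assay on L1.2 cells for binding affinity to C-C chemokine receptor type 8 (Homo sapiens) (on this read-out higher numbers stand for weaker inhibition and lower numbers for stronger inhibition), compound 1 gives 6.7 nM. Compound 2 `COCC(=O)N1CCC(NS(=O)(=O)c2ccc(NC(=O)c3ccccc3C)c3ccccc23)CC1` differs only in that a methoxy replaces a hydrogen on a saturated chain carbon bound to a carbonyl carbon; in this assay compound 2 gives 15.8 nM. The step of a 2.4-fold higher number from compound 1 to compound 2 (0.37 log units; beyond the scatter) is the only one on record, and it leaves compound 2 with the highest number of the two, compound 1 being its nearest neighbour.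

Compound 3 `Cc1ccccc1C(=O)Nc1ccc(S(=O)(=O)NC2CCN(C(=O)CN)CC2)c2ccccc12` is the next member: amino in place of methoxy on a saturated chain carbon bound to a carbonyl carbon. Within the data shown here, the only measured step that bears on this position is the one from compound 1 to compound 2, where a methoxy at this carbon gave a modest rise; no measured pair shows an amino at this position, so the direction of the new step cannot be read from the data. Given that the single relevant step was small, compound 3 is expected to stay close to compound 2, with the change a 1.1-fold lower number from compound 2 to compound 3 (0.02 log units; within the scatter) judged as none beyond the scatter. Compound 3 is therefore estimated at 15 nM in this assay, within a range of 5 nM to 45 nM.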

Compound 3, inhibition constant: 4.1 nM
The estimate for compound 3 lay 3.7-fold (0.56 log units) above the measured number; the measured number lies below the stated range.
By their numbers in this assay, from the lowest: compounds 3 and 1 (each within the scatter of the next); then compound 2.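

Replacing methoxy with amino on a saturated chain carbon bound to a carbonyl carbon gives a 3.9-fold lower number from compound 2 to compound 3 (0.59 log units; beyond the scatter) in this assay, so the rise seen with methoxy does not follow from every substituent placed on this carbon. Against the unsubstituted acetyl group, amino in place of hydrogen gives a 1.6-fold lower number from compound 1 to compound 3 (0.21 log units; within the scatter), which leaves compound 3 and compound 1 indistinguishable on this read-out, and this position accepts amino without a measurable cost, with compound 2 the only one of the three set apart. No supporting measurement accompanies these numbers that would account for the difference between methoxy and amino at this carbon.

The amino group brings one hydrogen-bond donor where methoxy has none, but a single pair cannot show whether that count or some other difference between the two groups goes with the step, and a hydroxy or a dimethylamino group on the same carbon would help to separate these readings. From the compounds shown here alone, how a longer chain carrying the amino group, or a carboxylic acid at this carbon, would read in this assay also stays open.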